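The compounds below may be only part of what the source reports. "The series", "measured", "known", "first", "only" and "open" are said of these compounds alone.

Compound 3 `CCc1cc(C(C)=O)c(O)cc1OCCCCCCC(=O)O` stands second highest of the three numbers in an assay on isolated protein for binding affinity to leukotriene B4 receptor 1 (Homo sapiens), tested at 1 uM (a lower number here means less inhibition, a higher number more inhibition at the concentration tested (going by the name of the read-out)), where compound 3 gives 38%. Compound 1 `CCc1cc(C(C)=O)c(O)cc1OCCCCC#N` gives 57% and compound 2 `CCc1cc(C(C)=O)c(O)cc1OCCCCCCCC(C)(C)C#N` gives 29%. Compound 4 `CCc1cc(C(C)=O)c(O)cc1OCCCCc1nnn[nH]1` has not yet been measured; the change from compound 3 is 1H-tetrazol-5-yl in place of 2-carboxyethyl on a saturated chain carbon, four bonds along the chain from an oxygen on an aromatic ring. Going by the values given here, two measured steps bear on this part of the molecule: a number 19 percentage points lower from compound 1 to compound 3 (beyond the scatter), and a number 9 percentage points higher from compound 2 to compound 3 (within the scatter). Compound 4 carries its new group at the same distance from the ring oxygen as the nitrile of compound 1, whose value is 57%, so a modest rise is expected, namely a number 7 percentage points higher from compound 3 to compound 4 (within the scatter). Compound 4 is therefore estimated at 45%, with a range from 25% to 65%.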

Compound 4, a percentage reported as inhibition, at one concentration (the size of the read-out at that concentration, not a potency): 19%
The estimate for compound 4 lay 26 percentage points above the measured number; measured number below the stated range.
By their numbers in this assay, from the lowest: compounds 4, 2 and 3 (each within the scatter of the next, the first and the last beyond it); then compound 1.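

In this assay, placing 1H-tetrazol-5-yl on the chain carbon gives a number 38 percentage points lower from compound 1 to compound 4 (beyond the scatter) and a number 19 percentage points lower from compound 3 to compound 4 (beyond the scatter), so the result seen with the nitrile does not carry over to this ring at the same place. The remaining step, a number 10 percentage points lower from compound 2 to compound 4 (within the scatter), leaves no order between those two compounds, even though their chains differ greatly in length. Nothing available explains the lower number for compound 4. As far as these compounds go, it remains open whether a primary amide at this place would stay nearer compound 1 or compound 4. The 2-(1H-tetrazol-5-yl)ethyl group, with its longer chain, also remains an open case.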